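Working notes: from compound 1 to compound 4

A few compounds are considered here, and "the series" means these few. Any claim that something is new, unique, unknown or untested is made for them only; others in the source may bear on it.

Compound 1 `CCOC(=O)c1cc(/C=C/c2cccc3ccccc23)on1` - > 128000 nM (limit)
Compound 2 `CCOC(=O)c1cc(/C=C/c2ccc(C(F)(F)F)cc2)on1` - "not determined" (no result reported)
Compound 3 `CCOC(=O)c1cc(/C=C\c2cc(F)cc(F)c2)on1` - > 128000 nM (limit)

In an ADME assay on Vero cells (Chlorocebus sabaeus) for cytotoxicity, with a stated time of 72 h (on this read-out lower numbers stand for stronger inhibition and higher numbers for weaker inhibition), compound 1 gives > 128000 nM as a limit of the assay and not as a number. Compound 3 gives > 128000 nM as a limit too. For the measured compounds named here, compound 1 therefore has no single number, and the series so far offers only the limit of > 128000 nM in this assay, at which 2 of the 3 values shown sit, for comparison.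

Compound 4 `CCOC(=O)c1cc(/C=C/c2ccc(C)c3ccccc23)on1` differs from compound 1 by methyl in place of hydrogen on an aromatic carbon, para to a large group (methyl in place of hydrogen on an aromatic carbon). Going by the values given here, no step between measured compounds is available to size this change. In this assay no step beyond the scatter is expected, and a further limit is the likeliest report for compound 4. That expectation rests on compound 1, whose > 128000 nM is a limit. The expected a number no higher from compound 1 to compound 4 (the limit leaves the size open) is correspondingly small and has no assigned direction. For compound 4 the estimated value is 128000 nM with an expected range of 50000 nM to 256000 nM in this read-out.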

Compound 4, half-maximal inhibitory concentration: > 128000 nM
Compound 4: no number, only a limit; the forecaster's own chance of this, stated with the estimate: 80%; the middle value lies on the limit itself.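

In this assay, no step can be read from compound 1 to compound 4; both give only a limit of the assay. The compounds shown leave open whether methyl in place of hydrogen on an aromatic carbon shifts this read-out at all, with the series resting on one limit: the limit of > 128000 nM in this assay, at which 3 of the 4 values shown sit.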